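Moving the Hydroxyl Around One Aryl Ring

The compounds below may be only part of what the source reports. "The series", "measured", "known", "first", "only" and "open" are said of these compounds alone.

Compound 1 `Oc1ccc(-c2cc(-c3ccccc3F)cc(-c3cccc(O)c3)n2)cc1` gives 14300 nM in a functional assay on HeLa cells (Homo sapiens) for inhibition; on this read-out higher numbers stand for weaker inhibition and lower numbers for stronger inhibition.
Compound 2 `Oc1ccccc1-c1cc(-c2cccc(C(F)(F)F)c2)cc(-c2ccccc2O)n1` gives only a limit, > 50000 nM, in this assay.
Compound 3 `Oc1ccc(-c2cc(-c3cccc(C(F)(F)F)c3)cc(-c3ccccc3O)n2)cc1` gives only a limit, > 50000 nM, in this assay.

Compound 3 therefore stands at the edge of what this assay can report: the limit of > 50000 nM in this assay, at which 2 of the 3 values shown sit, so its inhibition is weak but not pinned to a number. For the measured compounds named here, the one measured step that changes a single place, a step that the two limits leave unreadable from compound 2 to compound 3, runs from one limit to another and cannot be read for size.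

Compound 4 `Oc1ccc(-c2cc(-c3cccc(C(F)(F)F)c3)cc(-c3cccc(O)c3)n2)cc1` differs from compound 3 by 3-hydroxyphenyl in place of 2-hydroxyphenyl on an aromatic carbon. Going by the values given here, no measured step bears directly on this change. Compound 1 carries the same 3-hydroxyphenyl and 4-hydroxyphenyl groups and does return a number, but it differs from compound 4 in a second place, a 2-fluorophenyl where compound 4 has a 3-(trifluoromethyl)phenyl, so its value is only a rough pointer. Weak inhibition is expected for compound 4, possibly again a limit, with an estimated step of an at least 1.4-fold lower number from compound 3 to compound 4 (0.15 log units; that floor lies within the scatter). Compound 4 is expected at 35000 nM, within 10000 nM to 120000 nM.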

Compound 4, half-maximal inhibitory concentration: 16200 nM
Beside the measured number, compound 4's estimate is 2.2-fold (0.33 log units) above it, within the range that was stated.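

With the 3-(trifluoromethyl)phenyl and 4-hydroxyphenyl groups held fixed, the aryl ring next to the ring nitrogen now gives a readable result: 3-hydroxyphenyl in place of 2-hydroxyphenyl brings an at least 3.0-fold lower number from compound 3 to compound 4 (0.48 log units; beyond the scatter) and moves the pair from a limit onto a real number. That size is only a floor, because compound 3 has a limit rather than a number of its own: the limit of > 50000 nM in this assay, at which 2 of the 4 values shown sit. The change elsewhere on the core, 3-(trifluoromethyl)phenyl in place of 2-fluorophenyl, gives a 1.1-fold higher number from compound 1 to compound 4 (0.05 log units; within the scatter) and so, with 3-hydroxyphenyl at this position, the two compounds cannot be told apart on this read-out.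

Still open, from the compounds shown here alone, is whether the hydroxyl on this ring is needed at all, or whether a plain phenyl, a methoxy group, an amine or a carboxylic acid in its place would serve as well. Also open, going by these compounds, are how a 4-hydroxyphenyl group would read at this position, and whether the difference between 2-hydroxyphenyl and 3-hydroxyphenyl would hold with 2-fluorophenyl in place of 3-(trifluoromethyl)phenyl.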